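The source may report more compounds than this note shows. Statements on the series, on what has been measured and on what is new or still open speak of the compounds shown alone.

Of the compounds shown here, three built on a shared core have been measured in a functional assay on CWR22R cells (Homo sapiens) for antiproliferative activity, read by fluorescence and propidium iodide staining, with a stated time of 96 h; a lower number here means a stronger inhibitor, a higher number a weaker inhibitor. Compound 1 `O=C(Nc1ccc([N+](=O)[O-])c(C(F)(F)F)c1)c1ccc(Sc2ccc(O)cc2)cc1` gives 4500 nM in this assay. Compound 2 `O=C(Nc1cccc(S(F)(F)(F)(F)F)c1)c1ccc(Sc2ccc(O)cc2)cc1` differs from compound 1 elsewhere in the molecule, and the difference between the two cores is not broken down here. In this assay, for the measured compounds named here, compound 2 gives 2940 nM, a number that lies within the usual scatter of the one for compound 1. Compound 3 `O=C(Nc1ccc([N+](=O)[O-])c(C(F)(F)F)c1)c1ccc(S(=O)(=O)c2ccc(O)cc2)cc1` arises from compound 1 by one change, ((4-hydroxyphenyl)sulfonyl in place of (4-hydroxyphenyl)sulfanyl on an aromatic carbon), and in this assay compound 3 gives 7300 nM. The step of a 1.6-fold higher number from compound 1 to compound 3 (0.21 log units; within the scatter) therefore did not carry the number beyond the scatter. Compound 3 also stands above compound 2 by a gap that does exceed the scatter, though these two differ in more than one place.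

Compound 4 `O=C(Nc1cccc(S(F)(F)(F)(F)F)c1)c1ccc(S(=O)(=O)c2ccc(O)cc2)cc1` has not yet been measured. It relates to compound 2 as compound 3 relates to compound 1: (4-hydroxyphenyl)sulfonyl in place of (4-hydroxyphenyl)sulfanyl on an aromatic carbon. The surroundings of the place are described in identical words for both pairs, so this is the same change. Because the earlier step of a 1.6-fold higher number from compound 1 to compound 3 (0.21 log units; within the scatter) stayed within the scatter, the chemist expects compound 4 to show a similarly small step from compound 2, a 1.6-fold higher number from compound 2 to compound 4 (0.19 log units; within the scatter), in this assay. This expectation rests on a single prior comparison. The chemist's estimate for compound 4 in this assay is 4600 nM, with a range from 2200 nM to 9500 nM.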

Compound 4, half-maximal inhibitory concentration: 5660 nM
Compound 4: the middle estimate sits 1.2-fold (0.09 log units) below what was measured; measured number inside the range.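

In this assay, placing (4-hydroxyphenyl)sulfonyl where (4-hydroxyphenyl)sulfanyl stood gave a 1.9-fold higher number from compound 2 to compound 4 (0.28 log units; within the scatter), so on this second core, as on the core of compound 1, the step stays within the scatter. Set side by side, the two steps do not differ, and the change carries from one core to the other with the same small size: the same change on two cores in this assay, a 1.6-fold higher number (0.21 log units; within the scatter) from compound 1 to compound 3 and a 1.9-fold higher number (0.28 log units; within the scatter) from compound 2 to compound 4, 1.2-fold (0.07 log units) apart, within the scatter of two such steps

This shows that, on these two cores and in this one assay, the exchange of sulfanyl for sulfonyl leaves the number within the scatter, but since neither step exceeds the scatter, it does not establish that the change shifts the number at all, and two pairs make no rule for the wider series.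

The compounds shown leave open whether the same small step would hold on a core bearing a nitrile in place of the nitro group, or with a methoxy group or an amine in place of the hydroxyl on the 4-hydroxyphenyl group. They also leave open how a sulfinyl group in the same place would compare with the sulfanyl and sulfonyl pairs.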